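The source may hold more compounds than are shown below. What is called first, only, known or untested is meant among the compounds shown, and "the series" means these compounds.

Two analogues of a shared core have been run in a functional assay on the whole organism (strain Wistar albino) for inhibition, with Rattus norvegicus as the target, read by paw edema, with a stated time of 5 h, at a dose of 100 mg/kg by the oral route; on this read-out lower numbers stand for less inhibition and higher numbers for more inhibition at the one dose given (going by the name of the read-out). Compound 1 `Cc1ccc2c(Cc3nn4cc(-c5ccc(Br)cc5)nc4s3)coc2c1` gives 22.5% in this assay. Compound 2 `Cc1ccc2c(Cc3nn4c(C=O)c(-c5ccc(Cl)cc5)nc4s3)coc2c1` gives 48.8% in this assay, the highest of the two numbers, and its gap to compound 1 lies beyond the scatter. Compound 3 `Cc1ccc2c(Cc3nn4c(C=O)c(-c5ccc(Br)cc5)nc4s3)coc2c1` is not yet measured. Its change from compound 2 is bromo in place of chloro on an aromatic carbon, the same difference read one bond further out as 4-chlorophenyl to 4-bromophenyl. For the measured compounds named here, no measured pair isolates this exchange. The step of a number 3.8 percentage points lower from compound 2 to compound 3 (within the scatter) is expected to stay within the scatter, with no direction assumed. Compound 3 is estimated at 45%, between 30% and 58%.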

Compound 3, a percentage reported as inhibition, in the whole organism at one dose (the size of the read-out at that dose, not a potency): 12.4%
Estimate against measurement, compound 3: 32.6 percentage points above; the measured number lies below the stated range.
By their numbers in this assay, from the lowest: compound 3; then compound 1; then compound 2.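

In this assay the halogen exchange on the aromatic carbon para to a large group is not neutral: bromo in place of chloro gives a number 36.4 percentage points lower from compound 2 to compound 3 (beyond the scatter). With bromo held fixed, formyl in place of hydrogen gives a number 10.1 percentage points lower from compound 1 to compound 3 (beyond the scatter), so in this pair formyl does not raise the number. No measurement shown accounts for either step. Still open, going by these compounds, is how formyl acts alongside chloro, and whether a carboxylic acid in place of formyl or fluoro in place of chloro would keep the number of compound 2.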